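N-Alkyl variation in a bis(hydroxystyryl) enaminone series

The compounds below may be only part of what the source reports. "The series", "measured", "known", "first", "only" and "open" are said of these compounds alone.

Measured so far:
compound 1 `CCC(C)NC(=C\C(=O)/C=C/c1ccc(O)c(OC)c1)/C=C/c1ccc(O)c(OC)c1`: 184%
compound 2 `CC(C)CNC(=C\C(=O)/C=C/c1ccc(O)cc1)/C=C/c1ccc(O)cc1`: 119%
compound 3 `CCC(C)NC(=C\C(=O)/C=C/c1ccc(O)cc1)/C=C/c1ccc(O)cc1`: 414%

In a functional assay on EA.hy 926 cells (Homo sapiens), read by fluorescence, tested at 10 uM (a lower number here means a weaker effect, a higher number a stronger effect of the compound at the concentration tested), compound 3 gives the highest of the three numbers. Compound 1 lies nearest, compound 2 furthest, and both gaps are beyond the scatter, so compound 3 is the strongest of the measured set.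

Compound 4 `O=C(/C=C(/C=C/c1ccc(O)cc1)NC1CCCCC1)/C=C/c1ccc(O)cc1` keeps the core of compound 3 and changes only the group on the amine nitrogen: cyclohexyl in place of sec-butyl on an amine nitrogen.

Going by the values given here, one measured step bears on this position. The change from isobutyl to sec-butyl on the amine nitrogen gave a number 295 percentage points higher from compound 2 to compound 3 (beyond the scatter), a large step from a small alteration of the alkyl group. The variation to cyclohexyl is of the same kind, so a step beyond the scatter in this assay is expected for compound 4, but the measured data give no direction for a ring in place of an open chain. Because a number 295 percentage points higher from compound 2 to compound 3 (beyond the scatter) shows sensitivity at this position, a wide range is expected. For compound 4 the estimate is 280% (range 120% to 440%), an expected step of a number 134 percentage points lower from compound 3 to compound 4 (beyond the scatter).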

Compound 4, a percentage reported as activity, at one concentration (the size of the read-out at that concentration, not a potency): 299%
The estimate for compound 4 lay 19 percentage points below the measured number; low and high end bracket the measured number.
By their numbers in this assay, from the lowest: compound 2; then compound 1; then compound 4; then compound 3.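

In this assay, the amine nitrogen accepts a ring as well as an open chain without losing the effect: cyclohexyl gives a number 115 percentage points lower from compound 3 to compound 4 (beyond the scatter), yet also a number 180 percentage points higher from compound 2 to compound 4 (beyond the scatter). Compound 4 therefore falls inside the span set by the two open-chain groups, so the order of these three compounds does not follow group size alone, and sec-butyl remains the highest of them. Nothing available accounts for this order.

Still open, going by these compounds, is whether a smaller ring such as cyclopentyl, or a ring carrying oxygen such as tetrahydropyranyl, would come closer to sec-butyl or fall further away. On these data alone, it is also open whether cyclohexyl would keep the same standing relative to sec-butyl on the methoxy-bearing core of compound 1.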